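The source may report more compounds than this note shows. Statements on the series, on what has been measured and on what is new or still open speak of the compounds shown alone.

Measured so far in a functional assay on COLO 205 cells (Homo sapiens) for inhibition, read by sulforhodamine B assay, with a stated time of 48 h, tested at 50 uM; a lower number here means less inhibition of growth, a higher number more inhibition of growth at the concentration tested:
- compound 1 `COc1ccc2c(c1)C(=O)C(=O)N2CCCCn1cc(COc2cc(=O)oc3ccccc23)nn1` gives 41%
- compound 2 `O=C1C(=O)N(CCCCn2cc(COc3cc(=O)oc4ccccc34)nn2)c2ccccc21` gives 68%
- compound 3 `COc1ccc2c(c1)C(=O)C(=O)N2CCCn1cc(COc2cc(=O)oc3ccccc23)nn1` gives 48%

Compounds 1 and 2 differ in one place (hydrogen in place of methoxy on an aromatic carbon), and the step is a number 27 percentage points higher from compound 1 to compound 2 (beyond the scatter). Compound 3 carries a shorter linker than compound 1; the difference between the two cores is not broken down here, and the values of compound 1 and compound 3 lie within the scatter of each other.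

Compound 4 `O=C1C(=O)N(CCCn2cc(COc3cc(=O)oc4ccccc34)nn2)c2ccccc21` is not yet measured. It differs from compound 3 as hydrogen in place of methoxy on an aromatic carbon, the same change as between compound 1 and compound 2, at the same place. Because the earlier step was a number 27 percentage points higher from compound 1 to compound 2 (beyond the scatter), a step of similar size is expected from compound 3, namely a number 24 percentage points higher from compound 3 to compound 4 (beyond the scatter), with a single precedent only. Compound 4 is therefore estimated at 72% in this assay, within roughly 58% to 86%.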

Compound 4, percent growth inhibition at one concentration: 75%
For compound 4 the middle estimate is 3 percentage points below the measured one, and the stated range covers the measured number.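

In this assay, hydrogen in place of methoxy on an aromatic carbon gives a number 27 percentage points higher from compound 3 to compound 4 (beyond the scatter) and so repeats the earlier step on the core of compound 3. The two steps agree in size: the same change on two cores in this assay, a number 27 percentage points higher (beyond the scatter) from compound 1 to compound 2 and a number 27 percentage points higher (beyond the scatter) from compound 3 to compound 4, 0 percentage points apart, within the scatter of two such steps. The two cores differ only in linker length, so this shows the change carrying across that one difference at a single tested concentration; it does not show that the step would hold on a more distant core or in another assay, and it gives no cause for the step.

Other groups at this aromatic carbon, such as fluorine, chlorine or hydroxy, remain open. So does a longer chain in the linker.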